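The compounds below may be only part of what the source reports. "The series", "measured", "known", "first", "only" and "open" are said of these compounds alone.

Measured compounds:
compound 1 `Cc1nn(C)c(Oc2ccc(Br)cc2)c1/C=N\CCCCCCOc1cc2oc(=O)cc(C)c2cc1Cl`, which in a functional assay on HepG2 cells (Homo sapiens) for antiproliferative activity, read by MTT assay, with a stated time of 72 h (a higher number here means a weaker inhibitor, a lower number a stronger inhibitor), gives 4630 nM
compound 2 `Cc1ccccc1Oc1c(/C=N\CCCCCCOc2cc3oc(=O)cc(C)c3cc2Cl)c(C)nn1C`, which in this assay gives 7830 nM

Among the compounds with values here, of these two numbers, compound 2 has the larger, though the single step leading to it, a 1.7-fold higher number from compound 1 to compound 2 (0.23 log units; within the scatter), stays within the scatter. Compound 3 `Cc1nn(C)c(Oc2cccc(C(F)(F)F)c2)c1/C=N\CCCCCCOc1cc2oc(=O)cc(C)c2cc1Cl` differs from compound 2 by 3-(trifluoromethyl)phenyl in place of 2-methylphenyl on an oxygen on an aromatic ring. Within the data shown here, only that one measured step bears on this change, and it was small, so no step beyond the scatter is expected in this assay. Compound 3 is therefore estimated at 6000 nM, with a range from 2500 nM to 15000 nM. The expected step is a 1.3-fold lower number from compound 2 to compound 3 (0.12 log units; within the scatter).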

Compound 3, half-maximal inhibitory concentration: > 25000 nM
Compound 3 was reported as a limit; the forecaster's own chance of this, stated with the estimate: 5%; middle value at least 4.1-fold (0.61 log units) away from the limit.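

Compound 3 is reported in this assay only as a limit, not as a number: the limit of > 25000 nM in this assay, at which 1 of the 3 values shown sits. Even so, the group on this oxygen can now be seen to matter, as the earlier change stayed within the scatter. Here, 3-(trifluoromethyl)phenyl in place of 2-methylphenyl gives an at least 3.1-fold higher number from compound 2 to compound 3 (0.50 log units; beyond the scatter), and in place of 4-bromophenyl it gives an at least 5.3-fold higher number from compound 1 to compound 3 (0.73 log units; beyond the scatter), both beyond the scatter.

The compounds shown do not separate the effect of the trifluoromethyl group from that of its place on the ring. They also leave open how an amine or a carboxylic acid on this phenyl ring would behave.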